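Amide nitrogen substituents in the series: from compound 2 to compound 3

The source may hold more compounds than are shown below. What is called first, only, known or untested is meant among the compounds shown, and "the series" means these compounds.

Measured in a functional assay on MCF7 cells (Homo sapiens) for antiproliferative activity, read by MTT assay, with a stated time of 48 h; a higher number here means a weaker inhibitor, a lower number a stronger inhibitor:
- compound 1 `CCOc1ccc(NC(=O)c2ccc(C(CC)(CC)c3ccc(OCCC(O)(CC)CC)c(C)c3)n2CC)cc1`: > 50000 nM (a limit)
- compound 2 `CCC(C)C(NC(=O)c1ccc(C(CC)(CC)c2ccc(OCCC(O)(CC)CC)c(C)c2)n1CC)C(=O)OC`: > 50000 nM (a limit)

Compound 2 gives > 50000 nM in this assay, which is a limit of the assay and not a number. Within the data shown here, compound 1 stands in the same position, so the series so far is described by the limit of > 50000 nM in this assay, at which 2 of the 2 values shown sit. Among the measured compounds shown here, the only measured step is a step that the two limits leave unreadable from compound 1 to compound 2, and it offers no size to carry forward.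

The next compound is compound 3 `CCn1c(C(=O)NC(C)C(=O)O)ccc1C(CC)(CC)c1ccc(OCCC(O)(CC)CC)c(C)c1`. The change is a group of 5 heavy atoms (3 carbon, 2 oxygen; no ring) in place of a group of 9 heavy atoms (7 carbon, 2 oxygen; no ring), on an amide-type nitrogen. The shared core stays as it is, and the 1-carboxyethyl group is the smaller of the two groups by heavy atoms.

With no readable step to go on, no direction can be argued from the data. The expectation rests only on compound 2 with > 50000 nM, and a further limit reading is the likeliest result. The expected step is a step that the limit leaves unreadable from compound 2 to compound 3, and no clear move in either direction is expected. For compound 3 the estimate is 60000 nM, with an expected range of 20000 nM to 150000 nM.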

Compound 3, half-maximal inhibitory concentration: 19700 nM
Beside the measured number, compound 3's estimate is 3.0-fold (0.48 log units) above it; measured number below the stated range.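

In this assay, among these compounds, compound 3 gives 19700 nM, the first readable number, so a change on the amide-type nitrogen can give a readable number in this read-out. Compound 1 and compound 2 give no readable number, only a limit of the assay: the limit of > 50000 nM in this assay, at which 2 of the 3 values shown sit.

Putting 1-carboxyethyl on that nitrogen gives an at least 2.5-fold lower number from compound 2 to compound 3 (0.40 log units; beyond the scatter), and the same group in place of 4-ethoxyphenyl gives an at least 2.5-fold lower number from compound 1 to compound 3 (0.40 log units; beyond the scatter). Both sizes are lower bounds only, and the change from compound 2 to compound 3 is a double one: the entering group is smaller and carries a hydrogen-bond donor, where the leaving group has none.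

The compounds shown therefore do not separate the shorter chain from the free carboxylic acid as the source of the step. On these data alone, a methyl ester on the 1-carboxyethyl group and a free carboxylic acid on the longer chain of compound 2 would each change only one of these two features, and how either would read in this assay remains open.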